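Swapping the aryl group on a compound with mid-range clearance

This account rests on a few compounds, and the source may have more. Where it says the series, first, only, none or still open, it means among the compounds named here.

Measured in an ADME assay on liver for metabolic stability, with Liver microsome (Homo sapiens) as the target, using microsomes; a higher number here means faster removal of the compound, a lower number slower removal:
Compound 1 `COc1ccc(C(=O)Nc2[nH]nc(-c3ccccn3)c2C2CC2)cc1`: 12.8 mL.min-1.g-1
Compound 2 `O=C(Nc1cc(-c2ccccn2)n[nH]1)N1CCC(c2cccc(F)c2)CC1`: 25.3 mL.min-1.g-1

The two measured compounds differ in more than one place, and their values lie within the usual scatter of each other. Compound 1 therefore cannot be separated from compound 2 on these numbers, and the value of compound 2, 25.3 mL.min-1.g-1, is the starting point here.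

Compound 3 `N#Cc1ccc(C2CCN(C(=O)Nc3cc(-c4ccccn4)n[nH]3)CC2)cc1` has 4-cyanophenyl in place of 3-fluorophenyl on a saturated ring carbon. Within the data shown here, no measured pair shows what such an exchange does in this assay, so the expectation is only tentative. A small step towards a lower number is expected, scarcely beyond the scatter. The expected step is a 1.6-fold lower number from compound 2 to compound 3 (0.20 log units; within the scatter). For compound 3 the estimated value is 16 mL.min-1.g-1, with an expected range of 7 mL.min-1.g-1 to 35 mL.min-1.g-1.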

Compound 3, intrinsic clearance in microsomes: 25.3 mL.min-1.g-1
Estimate against measurement, compound 3: 1.6-fold (0.20 log units) below, and the stated range covers the measured number.
By their numbers in this assay, from the lowest: compounds 1, 2 and 3 (each within the scatter of the next).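

In this assay, 4-cyanophenyl in place of 3-fluorophenyl on a saturated ring carbon gives no change at the digits printed from compound 2 to compound 3 (within the scatter). Among these compounds, this is the first pair that differs in one place, and it shows that this position, three ring bonds from the ring nitrogen, can take 4-cyanophenyl, with a nitrile and a hydrogen-bond acceptor that 3-fluorophenyl lacks, without a step beyond the scatter. Nothing measured here explains why the two compounds read alike.

Since the substituent and its place on the phenyl ring change together, this pair cannot separate the two. Also open, as far as these compounds go, is how the same saturated ring carbon responds to a group that is not a substituted phenyl, such as a morpholine or a carboxylic acid.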